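Changing one five-membered ring on a shared core

The source may report more compounds than this note shows. Statements on the series, on what has been measured and on what is new or still open speak of the compounds shown alone.

Compound 1 `O=C(O)c1cc(-c2csnn2)ccc1O` was tested in a functional assay on the whole organism for inhibition, with Rattus norvegicus as the target, read by paw edema; a lower number here means that less compound is needed, a higher number that more compound is needed for the effect. In this assay compound 1 gives only > 200 mg/kg, which is a limit of the test and not a number. Two related compounds share its core. Compound 2 `O=C(O)c1cc(-c2nccs2)ccc1O` likewise reaches only > 250 mg/kg in this assay, again a limit rather than a number. Compound 3 `O=C(O)c1cc(-n2cccn2)ccc1O` gives 200 mg/kg in this assay. So compound 1 sits at a limit, as does one other of the three values, and the steps among them stay small or unreadable: a step that the two limits leave unreadable from compound 1 to compound 2, a number no higher from compound 1 to compound 3 (the limit leaves the size open), and an at least 1.2-fold lower number from compound 2 to compound 3 (0.09 log units; that floor lies within the scatter). Compound 4 `O=C(O)c1cc(-c2ccns2)ccc1O` differs from compound 1 in one place: 1,2-thiazol-5-yl in place of 1,2,3-thiadiazol-4-yl on an aromatic carbon. Within the data shown here, none of the measured steps tests this exact exchange, and every measured swap of this five-membered ring has left the dose close to the boundary of the test, as the limit of > 200 mg/kg in this assay, at which 1 of the 3 values shown sits, and the limit of > 250 mg/kg in this assay, at which 1 of the 3 values shown sits, show. Compound 4 is therefore expected to change little, a step that the limit leaves unreadable from compound 1 to compound 4, with an estimated dose of about 250 mg/kg, somewhere between 120 mg/kg and 500 mg/kg, and quite possibly reported again only as a limit.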

Compound 4, dose for half-maximal effect: 80 mg/kg
Beside the measured number, compound 4's estimate is 3.1-fold (0.49 log units) above it, and the stated range ends above it.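

Among the five-membered rings on the shared core, 1,2-thiazol-5-yl is the first to bring a clear gain in this assay, with an at least 2.5-fold lower number from compound 1 to compound 4 (0.39 log units; beyond the scatter) and an at least 3.1-fold lower number from compound 2 to compound 4 (0.49 log units; beyond the scatter). Among these compounds, the gain does not rest on limits alone, as the one step with a true number at both ends shows a 2.5-fold lower number from compound 3 to compound 4 (0.40 log units; beyond the scatter). This position is therefore not indifferent to the ring it carries: going from 1,2,3-thiadiazol-4-yl to 1,2-thiazol-5-yl leaves the heavy-atom count unchanged and trades a nitrogen for a carbon, yet the dose falls beyond the scatter.

From the compounds shown here alone, whether a methyl group or an amine added to the 1,2-thiazol-5-yl ring would keep this lower dose remains open. The full size of the step from compound 1 also stays unknown because its value is only a limit: the limit of > 200 mg/kg in this assay, at which 1 of the 4 values shown sits.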